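This account rests on a few compounds, and the source may have more. Where it says the series, first, only, none or still open, it means among the compounds named here.

In a physicochemical assay for solubility, read by nephelometry, measured as kinetic solubility (a higher number here means a more soluble compound, a lower number a less soluble compound), compound 1 `CC(=O)Nc1cnc2[nH]c(=O)n([C@H]3CC[C@H](C(C)(C)C)CC3)c(=O)c2c1` gives 310000 nM as its reading. Its mirror image, compound 2 `CC(=O)Nc1cnc2[nH]c(=O)n([C@H]3CC[C@@H](C(C)(C)C)CC3)c(=O)c2c1`, gives < 28000 nM and this is a limit of the assay, not a number. Compound 2 therefore stands at the low end of the two results. Going by the values given here, the one measured step is an at least 11-fold lower number from compound 1 to compound 2 (1.04 log units; beyond the scatter) and it comes about because of the fact that compounds 1 and 2 differ only in the configuration as drawn.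

Compound 3 `CC(=O)Nc1cnc2[nH]c(=O)n([C@H]3CC[C@@H](C(C)C)CC3)c(=O)c2c1` keeps the configuration drawn for compound 2 and changes it in one place (hydrogen in place of methyl on a saturated chain carbon bound to two saturated chain carbons and a saturated ring carbon). The same difference reads tert-butyl to isopropyl, with hydrogen in place of methyl on a saturated chain carbon bound to two saturated chain carbons and a saturated ring carbon.

Among the compounds with values here, no measured step covers this exchange. Only the large configuration step bears on it, and that step suggests compound 3 belongs with compound 2 rather than with compound 1. In this assay little movement is therefore expected, at most a small rise and perhaps none beyond the scatter. The expected step is an at least 1.2-fold higher number from compound 2 to compound 3 (0.09 log units; that floor lies within the scatter) and it remains only an estimate. In this assay compound 3 is estimated at 35000 nM with an expected range from 12000 nM to 110000 nM for the measurement to come.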

Compound 3, solubility: 15000 nM
The estimate for compound 3 lay 2.3-fold (0.37 log units) above the measured number; the measured number falls inside the stated range.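

No step can be read from compound 2 to compound 3 in this assay. Compound 2 gives < 28000 nM, which is a limit of the assay and not a number. The compounds shown leave open how far the change from tert-butyl to isopropyl moves the reading, and what it would do in the configuration drawn for compound 1.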